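Acetyl to dimethylamino on the pendant phenyl ring

The source may hold more compounds than are shown below. What is called first, only, known or untested is meant among the compounds shown, and "the series" means these compounds.

Three compounds of the series have numbers in a functional assay on HCT-116 cells (Homo sapiens) for cytotoxicity, read by sulforhodamine B assay, with a stated time of 48 h, tested at 10 uM; a lower number here means a stronger effect, a higher number a weaker effect of the compound at the concentration tested. Compound 1, with structure `COc1cc(C)cc(-c2c(-c3ccnc(-c4ccc(C(C)=O)cc4)c3)cnn2CC#N)c1`, gives -17% in this assay. Compound 2, `COc1cc(C)cc(-c2nn(CC#N)cc2-c2ccc(-c3cccc(C(C)=O)c3)nc2)c1`, gives -53%, and compound 3, `Cc1cc(O)cc(-c2nn(CC#N)cc2-c2ccnc(-c3ccc(Oc4ccccc4)cc3)c2)c1`, gives -97%. Compound 1 therefore stands highest of the three numbers shown; its nearest neighbour is compound 2, whose number lies beyond the scatter below it, and compound 3 lies furthest away, also beyond the scatter. Among the measured compounds shown here, no pair of these measured compounds differs in only one place, so no single-point step within the measured set can be read off.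

The next compound, compound 4 with structure `COc1cc(C)cc(-c2c(-c3ccnc(-c4ccc(N(C)C)cc4)c3)cnn2CC#N)c1`, differs from compound 1 in one place: dimethylamino in place of acetyl on an aromatic carbon. The acetyl group leaves and dimethylamino enters at the same aromatic carbon of the six-membered aromatic ring of carbon only; cut one bond further out this reads 4-acetylphenyl to 4-(dimethylamino)phenyl.

For the measured compounds named here, with no measured pair carrying this change, the expected size of the step in this assay is uncertain; a modest step towards a lower number, possibly not beyond the scatter, is the working expectation. The estimated step from compound 1 to compound 4 in this assay is a number 13 percentage points lower from compound 1 to compound 4 (beyond the scatter). For compound 4 in this assay the estimate is -30%, expected to fall between -70% and 10%.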

Compound 4, a percentage reported as activity, at one concentration (the size of the read-out at that concentration, not a potency): -27%
Estimate against measurement, compound 4: 3 percentage points below; measured number inside the range.
By their numbers in this assay, from the lowest: compound 3; then compound 2; then compounds 4 and 1 (each within the scatter of the next).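

Among the compounds shown here, compound 4 gives the first reading of a single change: in this assay the exchange of acetyl for dimethylamino on an aromatic carbon, para to a large group, amounts to a number 10 percentage points lower from compound 1 to compound 4 (within the scatter) and so gives no separation between the two groups at the concentration tested. The two groups match in their counts of heavy atoms and hydrogen-bond acceptors, and on the core of compound 1 this read-out does not tell a carbonyl-bearing group from a dimethylamino group at this place. No measurement at hand accounts for this likeness.

Steps from compound 1 or compound 4 to compound 2 and compound 3 cannot be read, as those compounds differ from them in more than one place, so the wider gaps in the numbers cannot be assigned to any one part of the structure. Also open, on these data alone, is whether a carboxylic acid, a primary amine or a longer chain such as methoxyethoxy on the same aromatic carbon would give a number beyond the scatter of compound 1, and a reading at one concentration gives no potency for any of these.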